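The source may report more compounds than this note shows. Statements on the series, on what has been measured and on what is new or still open speak of the compounds shown alone.

Working notes on the series. Three members of this series have been measured in an assay on isolated protein for binding affinity to adenosine receptor A1 (Bos taurus); on this read-out higher numbers stand for weaker inhibition and lower numbers for stronger inhibition. Compound 1 `CCNc1nc(-c2ccccc2)nc2c1nnn2Cc1ccccc1Cl` gives 463000000 nM. Compound 2 `CCCCCCNc1nc(-c2ccccc2)nc2c1nnn2Cc1ccccc1F` gives 25000000 nM. Compound 3 `OC1CCC(Nc2nc(-c3ccccc3)nc3c2nnn3Cc2ccccc2Cl)CC1` gives 3100000 nM, the lowest of the three numbers, with compound 2 the nearest and compound 1 the furthest. Within the data shown here, the one step between members that differ in a single place is a 150-fold lower number from compound 1 to compound 3 (2.17 log units; beyond the scatter), a large movement toward the lower numbers.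

Compound 4 `CCCCCCNc1nc(-c2ccccc2)nc2c1nnn2Cc1ccccc1Cl` is not yet measured in this assay. It differs from compound 3 by hexyl in place of 4-hydroxycyclohexyl on a nitrogen on an aromatic ring. Among the measured compounds shown here, no measured step covers this exact change, so the step from compound 1 to compound 3 bears on it only indirectly, as the sole evidence for how this position responds. Compound 2 carries the same hexyl group with a fluorine in place of the chlorine, and its number stands well above that of compound 3. Compound 4 is therefore expected to move back toward higher numbers, an estimated step of a 6.5-fold higher number from compound 3 to compound 4 (0.81 log units; beyond the scatter). The expected value for compound 4 in this assay is 20000000 nM, with a range from 5000000 nM to 100000000 nM.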

Compound 4, inhibition constant: 31000000 nM
Beside the measured number, compound 4's estimate is 1.6-fold (0.19 log units) below it; low and high end bracket the measured number.
By their numbers in this assay, from the lowest: compound 3; then compounds 2 and 4 (each within the scatter of the next); then compound 1.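

The hexyl group alone gives a 15-fold lower number from compound 1 to compound 4 (1.17 log units; beyond the scatter) in this assay against ethyl on the same core, so an open chain without a ring or a hydroxyl already carries this position well toward the lower numbers. The 4-hydroxycyclohexyl group still holds an advantage over that chain, with a 10-fold higher number from compound 3 to compound 4 (1.00 log units; beyond the scatter) for hexyl in its place, so the two groups are not interchangeable on this nitrogen. The pair carrying hexyl shows a 1.2-fold higher number from compound 2 to compound 4 (0.09 log units; within the scatter) for chloro in place of fluoro, so that swap on the aromatic carbon gives no readable change here.

No measurement on hand says what lies behind these movements. Going by these compounds, whether the lower number of compound 3 goes with the ring or with its hydroxyl stays open, and plain cyclohexyl on the same nitrogen would separate the two.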